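The source may report more compounds than this note shows. Statements on the series, on what has been measured and on what is new or still open speak of the compounds shown alone.

Of the compounds shown here, three built on one shared core have been tested in an ADME assay on MT4 cells (Homo sapiens) for cytotoxicity, read by MTT assay, with a stated time of 5 days; on this read-out higher numbers stand for lower toxicity in this test and lower numbers for higher toxicity in this test. Compound 1 `Cc1cc(C#N)cc(C)c1Oc1nc(Nc2ccc(C#N)cc2)ncc1-c1ccncc1` gives 28000 nM in this assay. Compound 2 `Cc1cc(C#N)cc(C)c1Oc1nc(Nc2ccc(C#N)cc2)ncc1-c1ccc(N)cc1` gives 310 nM, and compound 3 `Cc1cc(C#N)cc(C)c1Oc1nc(Nc2ccc(C#N)cc2)ncc1-c1ccsc1` gives 3920 nM. On these numbers compound 3 stands second highest of the three; it lies nearest to compound 1 and furthest from compound 2, and the gaps are a 7.1-fold lower number from compound 1 to compound 3 (0.85 log units; beyond the scatter) and a 13-fold higher number from compound 2 to compound 3 (1.10 log units; beyond the scatter).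

Compound 4 `Cc1cc(C#N)cc(C)c1Oc1nc(Nc2ccc(C#N)cc2)ncc1-c1ccoc1` has not yet been measured. It differs from compound 3 in one place: furan-3-yl in place of thiophen-3-yl on an aromatic carbon. Within the data shown here, no measured step swaps one five-membered ring for another, so none bears directly on this change. The two steps that reach compound 3 each replace a ring of a different kind, and both move the number beyond the scatter, one modest and one large. The change into compound 4 is much smaller: the group that leaves and the group that enters share the ring form and the same counts of heavy atoms, donors and acceptors. The step expected in this assay is therefore small, in no clear direction, and probably within the scatter. Compound 4 is expected to give about 4000 nM, within a range from 1500 nM to 10000 nM, which means an expected step of a 1.0-fold higher number from compound 3 to compound 4 (0.01 log units; within the scatter).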

Compound 4, half-maximal cytotoxic concentration: 4980 nM
Compound 4: middle estimate off by 1.2-fold (0.10 log units), on the low side; the range from low to high includes it.
By their numbers in this assay, from the lowest: compound 2; then compounds 3 and 4 (each within the scatter of the next); then compound 1.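

In this assay, among these compounds, putting the oxygen of furan-3-yl where the sulfur of thiophen-3-yl stood gives a 1.3-fold higher number from compound 3 to compound 4 (0.10 log units; within the scatter) and so leaves the number within the scatter, which makes this the first pair of five-membered rings seen at this position and shows that the test does not separate them. Compound 4 also confirms what compound 3 alone could only suggest: with a 16-fold higher number from compound 2 to compound 4 (1.21 log units; beyond the scatter) and a 5.6-fold lower number from compound 1 to compound 4 (0.75 log units; beyond the scatter) on record, both five-membered rings lie between the 4-aminophenyl and pyridin-4-yl compounds, and the gap to each is beyond the scatter. No measurement at hand explains why the two hetero atoms read alike here or why the three kinds of ring differ.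

As far as these compounds go, it remains open whether a five-membered ring with a second hetero atom, such as thiazole or imidazole, would still fall with compounds 3 and 4. A plain phenyl ring would also be informative, since its number could show whether compound 2 owes its place to the amine on its ring, and a pyridin-3-yl group could do the same for the ring nitrogen of compound 1.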